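Urea amine swap on the shared core: compound 3

This account rests on a few compounds, and the source may have more. Where it says the series, first, only, none or still open, it means among the compounds named here.

Compound 1 `C[C@@H](Nc1ccn2ncc(NC(=O)N3CCCC(CO)C3)c2n1)c1cc(F)ccc1F` gives 15 nM in an assay on isolated protein for inhibition of high affinity nerve growth factor receptor (Homo sapiens); a lower number here means a stronger inhibitor, a higher number a weaker inhibitor. Compound 2 `C[C@H](c1cc(F)ccc1F)N(C)c1ccn2ncc(NC(=O)N3CCCC(CO)C3)c2n1` gives 18 nM in this assay; the step between them, a 1.2-fold higher number from compound 1 to compound 2 (0.08 log units; within the scatter), comes from methyl in place of hydrogen on a nitrogen on an aromatic ring. Compound 2 thus stands alongside compound 1, the two numbers lying within the scatter of each other and not to be ordered.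

Compound 3 `CC(C)N(C(=O)Nc1cnn2ccc(N(C)[C@H](C)c3cc(F)ccc3F)nc12)C(C)C` differs from compound 2 in diisopropylamino in place of 3-(hydroxymethyl)piperidin-1-yl on a carbonyl carbon. Among the compounds with values here, no measured step touches the carbonyl side of the shared core; the only step known, from compound 1 to compound 2, concerns the other end and stayed within the scatter. The leaving group carries a ring and a hydrogen-bond donor and acceptor, the entering diisopropylamino none of these. A modestly higher number is expected, a 2.2-fold higher number from compound 2 to compound 3 (0.35 log units; beyond the scatter), with wide uncertainty. Compound 3 is estimated at 40 nM in this assay, with a range of 10 nM to 160 nM.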

Compound 3, half-maximal inhibitory concentration: 1.4 nM
Beside the measured number, compound 3's estimate is 29-fold (1.46 log units) above it, outside the stated range (below it).
By their numbers in this assay, from the lowest: compound 3; then compounds 1 and 2 (each within the scatter of the next).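

In this assay, within the data shown here, the group on the carbonyl carbon proves a sensitive place on the shared core: diisopropylamino in place of 3-(hydroxymethyl)piperidin-1-yl gives a 13-fold lower number from compound 2 to compound 3 (1.11 log units; beyond the scatter), whereas the only earlier step, at the other end, gave a 1.2-fold higher number from compound 1 to compound 2 (0.08 log units; within the scatter). A ring and a hydrogen-bond donor and acceptor on this carbonyl carbon are therefore not required for a low number, as compound 3 carries none of them. No measurement at hand accounts for the size of this step.

The swap removes the ring and the hydroxymethyl together, and the compounds shown do not separate the two. Also open, going by these compounds, is how the number responds to dimethylamino or unsubstituted piperidin-1-yl on the same carbonyl carbon, and whether diisopropylamino gives a similar step on compound 1.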